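This account rests on a few compounds, and the source may have more. Where it says the series, first, only, none or still open, it means among the compounds named here.

The three measured compounds share the core of compound 1 `Cn1c(-c2ccc(NC(=O)CSc3nc4ccccc4o3)cc2)nc(-c2ccccc2)c1-c1ccccc1` and differ only in the group carried on a sulfur at the end of the chain. In a functional assay on HT-29 cells (Homo sapiens) for cytotoxicity, read by MTT assay, with a stated time of 24 h, tested at 32 ug/mL (on this read-out lower numbers stand for a weaker effect and higher numbers for a stronger effect at the one concentration tested), compound 1 gives 79.3%. Compound 2 `Cn1c(-c2ccc(NC(=O)CSc3nc4ccccc4s3)cc2)nc(-c2ccccc2)c1-c1ccccc1` gives 66%, and compound 3 `Cn1c(-c2ccc(NC(=O)CSC3=NCCS3)cc2)nc(-c2ccccc2)c1-c1ccccc1` gives 59.4%. Compound 3 stands lowest of the three numbers: the step of a number 6.6 percentage points lower from compound 2 to compound 3 (within the scatter) is within the scatter, whereas a number 19.9 percentage points lower from compound 1 to compound 3 (beyond the scatter) and the related a number 13.3 percentage points lower from compound 1 to compound 2 (beyond the scatter) lie beyond it. Compound 4 `CCN1CCN(CC(=O)Nc2ccc(-c3nc(-c4ccccc4)c(-c4ccccc4)n3C)cc2)CC1` is the next compound to consider. It differs from compound 3 in one place: a group of 8 heavy atoms (6 carbon, 2 nitrogen; one six-membered non-aromatic ring with 2 hetero atoms) in place of a group of 6 heavy atoms (3 carbon, 1 nitrogen, 2 sulfur; one five-membered non-aromatic ring with 2 hetero atoms), on a saturated chain carbon bound to a carbonyl carbon. For the measured compounds named here, none of the measured steps covers this exchange; each of them replaced one group by another on the sulfur, with the sulfur itself retained, whereas here the whole group with its sulfur atoms leaves and a 4-ethylpiperazin-1-yl enters on the saturated chain carbon bound to the carbonyl carbon. Going by the values given here, the measured steps show only that exchanges at this end of the chain moved the read-out by modest amounts. Among the compounds with values here, one therefore expects no step clearly beyond the scatter, while allowing a modest move in either direction and a wide range. For compound 4 the estimated value is 55%, with a range from 30% to 80%. The expected step of a number 4.4 percentage points lower from compound 3 to compound 4 (within the scatter) is thus small.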

Compound 4, a percentage reported as activity, at one concentration (the size of the read-out at that concentration, not a potency): 38.8%
For compound 4 the middle estimate is 16.2 percentage points above the measured one, and the stated range covers the measured number.
By their numbers in this assay, from the lowest: compound 4; then compounds 3 and 2 (each within the scatter of the next); then compound 1.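

In this assay, replacing the whole sulfur-bearing group with 4-ethylpiperazin-1-yl on a saturated chain carbon bound to a carbonyl carbon gives a number 20.6 percentage points lower from compound 3 to compound 4 (beyond the scatter), a number 27.2 percentage points lower from compound 2 to compound 4 (beyond the scatter) and a number 40.5 percentage points lower from compound 1 to compound 4 (beyond the scatter). Unlike the earlier exchanges, which kept the sulfur and changed only the group on it, this change removes the sulfur as well, and it leaves compound 4 clearly lowest of the four, since all three of its steps lie beyond the scatter. The position therefore responds to an exchange of the entire group, but nothing shown explains the fall, and no supporting evidence bears on it.

The compounds shown do not separate the contribution of the piperazine ring from that of its ethyl group, or the loss of the sulfur from the arrival of the new ring, so piperazin-1-yl, morpholin-4-yl or diethylamino on the same carbon would each address a different part of the question. As far as these compounds go, it also remains open whether 4-ethylpiperazin-1-yl would give a similar number if attached through a longer chain, and a reading at one concentration leaves the potency of all four compounds undefined.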